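The source may report more compounds than this note shows. Statements on the series, on what has been measured and on what is new or still open speak of the compounds shown alone.

Measured compounds in a functional assay on CHO cells for agonist activity at Free fatty acid receptor 1 (Homo sapiens), read by a luciferase reporter; on this read-out lower numbers stand for smaller maximal responses and higher numbers for larger maximal responses:

- compound 1, `O=C(O)COc1ccc(NCc2cccc(Oc3ccccc3)c2)cc1`: 84%
- compound 2, `CC(C)(Oc1ccc(NCc2cccc(Oc3ccccc3)c2)cc1)C(=O)O`: 14%
- compound 3, `CNC(=O)CCc1ccc(NCc2cccc(Oc3ccccc3)c2)cc1`: 67%

Compound 3 stands second highest of the three numbers. Its nearest neighbour on the read-out is compound 1, with a number 17 percentage points lower from compound 1 to compound 3 (beyond the scatter); the furthest is compound 2, with a number 53 percentage points higher from compound 2 to compound 3 (beyond the scatter). Among the compounds with values here, the large drop a number 70 percentage points lower from compound 1 to compound 2 (beyond the scatter) concerns the acid-bearing side chain on an oxygen and is the only other step in the set.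

Compound 4, `CC(C)NC(=O)CCc1ccc(NCc2cccc(Oc3ccccc3)c2)cc1`, is to be measured in this assay. It differs from compound 3 in one place: isopropyl in place of methyl on an amide-type nitrogen. Within the data shown here, none of the measured steps touches the amide-type nitrogen; all three change the group on the aromatic carbon, so no step bears directly on this change. The methylcarbamoyl compound 3 already sits well above compound 2 and not far below compound 1, and there is nothing here to argue for a move in either direction beyond the scatter. A step of a number 5 percentage points lower from compound 3 to compound 4 (within the scatter) is therefore expected, within or near the scatter. Compound 4 is estimated at 62%, in a range of 38% to 85%.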

Compound 4, largest response reached (reported as percent of maximum), in percent of the reference or control that the assay uses: 66%
For compound 4 the middle estimate is 4 percentage points below the measured one; the range from low to high includes it.
By their numbers in this assay, from the lowest: compound 2; then compounds 4 and 3 (each within the scatter of the next); then compound 1.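

Within the data shown here, on the amide-type nitrogen, the maximal response does not separate isopropyl from methyl (a number 1 percentage points lower from compound 3 to compound 4 (within the scatter)), which gives the first reading at this position in this assay. The 2-(isopropylcarbamoyl)ethyl group stands clear of both acid side chains, well above the 1-carboxy-1-methylethoxy compound (a number 52 percentage points higher from compound 2 to compound 4 (beyond the scatter)) and modestly below the carboxymethoxy compound (a number 18 percentage points lower from compound 1 to compound 4 (beyond the scatter)), so the placing of the methylcarbamoyl compound 3 between them holds for the isopropyl amide compound 4. No measurement at hand bears on the reason for this result.

A single pair at this nitrogen gives no trend, and a bulkier group such as tert-butyl or cyclohexyl could read differently. As far as these compounds go, a primary amide, with hydrogen alone on the nitrogen, or a chain there ending in an amine or a carboxylic acid remains open as well.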